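A few compounds are considered here, and "the series" means these few. Any claim that something is new, unique, unknown or untested is made for them only; others in the source may bear on it.

Compound 1 is `CC(=O)Nc1ccc(/C=N/Nc2nc(N)c3ncn([C@@H]4O[C@H](CO)[C@@H](O)[C@H]4O)c3n2)cc1`. In an assay on CHO-K1 cells for displacement of a labelled ligand from adenosine receptor A1 (Homo sapiens), read by scintillation counting, with a stated time of 60 min (a lower number here means a stronger inhibitor, a higher number a weaker inhibitor), compound 1 gives > 10000 nM, which is a limit of the assay and not a number. Compound 1 therefore stands at the limit of > 10000 nM in this assay, at which 1 of the 3 values shown sits, and its position is known only as a bound. Compound 2, `Nc1nc(N/N=C/c2cncs2)nc2c1ncn2[C@@H]1O[C@H](CO)[C@@H](O)[C@H]1O`, carries 1,3-thiazol-5-yl on the carbon with a double bond to nitrogen; in this assay compound 2 gives 22 nM, and the step is an at least 450-fold lower number from compound 1 to compound 2 (2.65 log units; beyond the scatter). Compound 3, `Nc1nc(N/N=C/c2ccc(-c3ccccn3)cc2)nc2c1ncn2[C@@H]1O[C@H](CO)[C@@H](O)[C@H]1O`, keeps the phenyl ring and exchanges acetamido for pyridin-2-yl; in this assay compound 3 gives 7540 nM, and the step is an at least 1.3-fold lower number from compound 1 to compound 3 (0.12 log units; that floor lies within the scatter).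

Compound 4 is `Nc1nc(N/N=C/c2ccc(Br)cn2)nc2c1ncn2[C@@H]1O[C@H](CO)[C@@H](O)[C@H]1O`. The change from compound 1 is 5-bromopyridin-2-yl in place of 4-acetamidophenyl on a carbon with a double bond to nitrogen. The step of an at least 450-fold lower number from compound 1 to compound 2 (2.65 log units; beyond the scatter) bears most directly, as it too replaces the whole 4-acetamidophenyl with a smaller heteroaromatic ring, whereas the step of an at least 1.3-fold lower number from compound 1 to compound 3 (0.12 log units; that floor lies within the scatter) retains the phenyl ring and moves little. Among the measured compounds shown here, a large step down in this assay is therefore expected for compound 4, though a bromine-bearing ring has no measured precedent here. The expected step is an at least 100-fold lower number from compound 1 to compound 4 (2.00 log units; beyond the scatter). Compound 4 is estimated at 100 nM, within 15 nM to 1500 nM.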

Compound 4, inhibition constant: 4.7 nM
Compound 4: the middle estimate sits 21-fold (1.33 log units) above what was measured; the measured number lies below the stated range.
By their numbers in this assay, from the lowest: compound 4; then compound 2; then compound 3. At a limit, above all of these: compound 1.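

In this assay, 5-bromopyridin-2-yl gives a second case of replacing the whole 4-acetamidophenyl on the carbon with a double bond to nitrogen, and the step is an at least 2100-fold lower number from compound 1 to compound 4 (3.32 log units; beyond the scatter). Compound 1 is a limit of the assay and not a number, so that step is only a floor: the limit of > 10000 nM in this assay, at which 1 of the 4 values shown sits. The exchange between the two heteroaromatic groups also moves the number, with a 4.7-fold lower number from compound 2 to compound 4 (0.67 log units; beyond the scatter), so this position distinguishes between such rings and does not merely register the loss of 4-acetamidophenyl.

The compounds shown cannot separate the share of the bromine from that of the pyridine ring, since both enter together. A pyridin-2-yl without bromine, or one carrying chlorine, methoxy or an amine in its place, would address that question.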